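This account rests on a few compounds, and the source may have more. Where it says the series, first, only, none or still open, it means among the compounds named here.

Measured so far:
compound 1 `N#Cc1ccccc1COc1cc(O)c2c(=O)c(O)c(-c3ccccc3)oc2c1` — 22000 nM
compound 2 `COc1cccc(COc2cc(O)c3c(=O)c(O)c(-c4ccccc4)oc3c2)c1` — > 100000 nM

In an ADME assay on Huh-5-2 cells (Homo sapiens) for cytotoxicity, read by WST assay, with a stated time of 3 days (a higher number here means that more compound is tolerated, a lower number that less compound is tolerated), compound 1 gives 22000 nM. Compound 2 gives only a limit, > 100000 nM, which is the assay limit of > 100000 nM in this assay, at which 1 of the 2 values shown sits, and not a number. Among the measured compounds shown here, the single measured step, an at least 4.5-fold higher number from compound 1 to compound 2 (0.65 log units; beyond the scatter), is the only guide. Compound 3 `O=c1c(O)c(-c2ccccc2)oc2cc(OCc3ccc(Cl)cc3)cc(O)c12` differs from compound 2 by 4-chlorophenyl in place of 3-methoxyphenyl on a saturated chain carbon bound to an oxygen on an aromatic ring. For the measured compounds named here, no measured step covers this exchange, so the expectation leans on compound 2 alone and allows a small downward move. Compound 3 is expected near 80000 nM, within 30000 nM to 200000 nM. The expected step is an at least 1.2-fold lower number from compound 2 to compound 3 (0.09 log units; that floor lies within the scatter).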

Compound 3, half-maximal cytotoxic concentration: > 100000 nM
Compound 3: no number, only a limit; the forecaster's own chance of this, stated with the estimate: 45%; middle value at least 1.2-fold (0.09 log units) away from the limit.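

In this assay compound 3 gives > 100000 nM, which is a limit and not a number. A second replacement for 2-cyanophenyl on the saturated chain carbon, this time 4-chlorophenyl, gives an at least 4.5-fold higher number from compound 1 to compound 3 (0.65 log units; beyond the scatter), so the higher number is not confined to 3-methoxyphenyl. The step between compound 2 and compound 3 cannot be read, both values sitting at one limit: the limit of > 100000 nM in this assay, at which 2 of the 3 values shown sit.

Any difference between 3-methoxyphenyl and 4-chlorophenyl stays hidden in this assay. On these data alone, how a phenyl ring carrying an amine or a carboxylic acid would read at this place remains open.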